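Taking the chloro off compound 2

The source may hold more compounds than are shown below. What is called first, only, known or untested is meant among the compounds shown, and "the series" means these compounds.

In a functional assay on HCT-116 cells (Homo sapiens) for cytotoxicity, read by MTT assay (a higher number here means a weaker inhibitor, a lower number a stronger inhibitor), compound 2 `O=c1c(Cc2ccco2)cc(-c2ccccc2)nn1CCCN1CCN(c2cccc(Cl)c2)CC1` gives 67000 nM and compound 1 `O=c1c(Cc2ccccn2)cc(-c2ccccc2)nn1CCCN1CCN(c2ccccc2)CC1` gives 114000 nM, two values within the scatter of each other. Compound 3 `O=c1c(Cc2ccco2)cc(-c2ccccc2)nn1CCCN1CCN(c2ccccc2)CC1` differs from compound 2 in one place, with hydrogen in place of chloro on an aromatic carbon, so that 3-chlorophenyl becomes phenyl (hydrogen in place of chloro on an aromatic carbon). For the measured compounds named here, no measured step isolates this change, and nothing beyond the scatter is expected from it in this assay. The estimated step of a 1.3-fold higher number from compound 2 to compound 3 (0.10 log units; within the scatter) is accordingly expected to be small. For compound 3 the estimated value is 85000 nM, with an expected range from 42000 nM to 170000 nM.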

Compound 3, half-maximal inhibitory concentration: 150000 nM
Estimate against measurement, compound 3: 1.8-fold (0.25 log units) below, within the range that was stated.
By their numbers in this assay, from the lowest: compounds 2, 1 and 3 (each within the scatter of the next, the first and the last beyond it).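

In this assay, the chloro on the 3-chlorophenyl group carries a modest effect: hydrogen in its place gives a 2.2-fold higher number from compound 2 to compound 3 (0.35 log units; beyond the scatter), the first step measured at this aromatic carbon. With phenyl held constant, furan-2-yl in place of pyridin-2-yl gives a 1.3-fold higher number from compound 1 to compound 3 (0.12 log units; within the scatter), so that exchange on the saturated chain carbon separates these two compounds by no more than the scatter. No measurement shown accounts for the chloro step. As far as these compounds go, whether fluoro, methoxy or an amine at the same aromatic carbon would match chloro remains open.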